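Replacing the dibromophenyl group of compound 3

The source may report more compounds than this note shows. Statements on the series, on what has been measured and on what is new or still open speak of the compounds shown alone.

In a physicochemical assay for solubility, in phosphate buffer, measured as kinetic solubility, at pH 7.4 (on this read-out lower numbers stand for lower solubility and higher numbers for higher solubility), compound 3 `Cc1oc(-c2c(Br)cccc2Br)nc1CN1CCC(C(=O)NCCCN2C[C@H](C)C[C@H](C)C2)CC1` gives 62.4 ug/mL while compound 1 `Cc1ccc(C)c(-c2nc(CN3CCC(C(=O)NCCCN4C[C@H](C)C[C@H](C)C4)CC3)c(C)o2)c1` gives 56.1 ug/mL and these two numbers lie within the scatter of each other. Compound 2 `Cc1ccccc1-c1nc(CN2CCC(C(=O)NCCCN3CCCC(C(C)C)C3)CC2)c(C)o1` reports > 71 ug/mL as a limit of the assay and not a number.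

Compound 4 `Cc1cccc(-c2nc(CN3CCC(C(=O)NCCCN4C[C@H](C)C[C@H](C)C4)CC3)c(C)o2)c1` differs from compound 3 by a single change: 3-methylphenyl in place of 2,6-dibromophenyl on an aromatic carbon. Within the data shown here, one measured step bears on this place, the exchange of 2,5-dimethylphenyl for 2,6-dibromophenyl, which gave a 1.1-fold higher number from compound 1 to compound 3 (0.05 log units; within the scatter) and so stayed small. Among the measured compounds shown here, that is only one step, but it offers no reason to expect a clear shift, so no change beyond the scatter is expected in this assay here. The expected step is a 1.0-fold lower number from compound 3 to compound 4 (0.02 log units; within the scatter) and it should be read as an estimate only. Compound 4 is estimated at 60 ug/mL with an expected range from 35 ug/mL to 75 ug/mL in this read-out.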

Compound 4, solubility: > 69 ug/mL
Compound 4 was reported as a limit (the forecaster's own chance of this, stated with the estimate: 25%); at least 1.1-fold (0.06 log units) between middle value and limit.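

In this assay compound 4 gives > 69 ug/mL, which is a limit of the assay and not a number. From the compounds shown here alone, the steps to it therefore give only floors, an at least 1.1-fold higher number from compound 3 to compound 4 (0.04 log units; that floor lies within the scatter) and an at least 1.2-fold higher number from compound 1 to compound 4 (0.08 log units; that floor lies within the scatter), so the true size of either change stays unknown. What is new is that a phenyl ring with a single methyl and no bromine at this place, on the carbon of the five-membered ring next to the ring nitrogen and ring oxygen, gives a reading that sits at a limit: the limit of > 69 ug/mL in this assay, at which 1 of the 4 values shown sits.

Going by these compounds, how far compound 4 really lies from compound 1 and compound 3 remains open. Also open, on these data alone, is what a phenyl ring carrying an amine or a carboxylic acid would give at this place.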